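This account rests on a few compounds, and the source may have more. Where it says the series, first, only, none or still open, it means among the compounds named here.

Measured so far:
- compound 1, `Cc1cccc(N(C)CC2CCC/C(=C\c3ccccc3)C2=O)c1`: 44.9%
- compound 2, `Cc1ccc(/C=C2\CCCC(CN(C)c3ccc(C)cc3)C2=O)cc1`: 27.6%

In a functional assay on the whole organism (Ear, strain Kunming) for inhibition, with Mus musculus as the target, with stated times of 1 h and 30 min, at a dose of 200 mg/kg by the oral route (a higher number here means more inhibition at the dose given (going by the name of the read-out), a lower number less inhibition), compound 1 gives 44.9%. In this assay compound 2 gives 27.6%, the lower of the two numbers; the gap to compound 1 lies beyond the usual scatter of the measurement. Among the compounds with values here, compound 1 and compound 2 differ at more than one place, so no single step is counted for that pair and only the two values themselves can be read.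

The next compound is compound 3, `Cc1ccc(/C=C2\CCCC(CN(C)c3cccc(C)c3)C2=O)cc1`, not yet measured. It differs from compound 2 in one place: 3-methylphenyl in place of 4-methylphenyl on an amine nitrogen. The group that enters is the same one that compound 2's stronger neighbour, compound 1, carries on its amine nitrogen, while the rest of compound 3 stays as in compound 2. Within the data shown here, no measured pair isolates this change, so the expectation rests only on where compound 1 and compound 2 stand.

A moderate rise is expected for compound 3, as a number 8.4 percentage points higher from compound 2 to compound 3 (within the scatter), leaning toward compound 1 with 44.9% but not assumed to reach it. Compound 3 is estimated at 36%, with a range from 22% to 50%.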

Compound 3, a percentage reported as inhibition, in the whole organism at one dose (the size of the read-out at that dose, not a potency): 35.4%
The estimate for compound 3 lay 0.6 percentage points above the measured number, and the stated range covers the measured number.
By their numbers in this assay, from the lowest: compounds 2, 3 and 1 (each within the scatter of the next, the first and the last beyond it).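

In this assay, 3-methylphenyl in place of 4-methylphenyl on the amine nitrogen gives a number 7.8 percentage points higher from compound 2 to compound 3 (within the scatter) and so, for two groups with the same count of atoms, this exchange alone is not separated from the usual scatter. Methyl in place of hydrogen on an aromatic carbon, read here for the first time as a single change, gives a number 9.5 percentage points lower from compound 1 to compound 3 (within the scatter) and also stays inside the scatter. Compound 3 thus links compound 1 and compound 2 through two single changes, and the gap beyond the scatter between those two compounds appears only when both changes are taken together.

Still open, going by these compounds, is whether a group other than methyl on the phenyl at the amine nitrogen, such as methoxy or a chlorine atom, would give a step beyond the scatter at this position. Also open, on these data alone, is how the phenyl on the amine nitrogen reads with no methyl at all, and whether the two changes would add up in the same way on that compound. Nothing measured in the series speaks to why these numbers fall where they do.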